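A few compounds are considered here, and "the series" means these few. Any claim that something is new, unique, unknown or untested is made for them only; others in the source may bear on it.

Compound 2 (`COc1ccc2c(=O)c(/C=C/C(=O)NCc3ccc(F)cc3)coc2c1`) sits at the edge of what the assay reports. In a functional assay on A549 cells (Homo sapiens) for inhibition, read by MTT assay, with a stated time of 48 h (on this read-out higher numbers stand for weaker inhibition and lower numbers for stronger inhibition), compound 2 gives > 100000 nM, which is a limit of the assay rather than a number, as noted in the limit of > 100000 nM in this assay, at which 1 of the 2 values shown sits. Compound 1 (`COc1ccc2c(=O)c(/C=C/C(=O)NCc3ccccc3)coc2c1`) gives 11800 nM in this assay. For the measured compounds named here, the only measured step, an at least 8.4-fold higher number from compound 1 to compound 2 (0.92 log units; beyond the scatter), involved fluoro in place of hydrogen on an aromatic carbon. Compound 3 (`COc1ccc2c(=O)c(/C=C/C(=O)Nc3ccc(Cl)cc3)coc2c1`) differs from compound 2 by 4-chlorophenyl in place of 4-fluorobenzyl on an amide-type nitrogen, a change of a different kind. No measured step matches this change, and since compound 2 is known only as a limit, the size and direction of the step cannot be fixed from the numbers shown. Compound 3 is therefore expected near 60000 nM, within a broad range of 15000 nM to 250000 nM, implying an estimated step of an at least 1.6-fold lower number from compound 2 to compound 3 (0.22 log units; that floor lies within the scatter).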

Compound 3, half-maximal inhibitory concentration: > 100000 nM
Compound 3: only a limit was reported; the forecaster's own chance of this, stated with the estimate: 50%; middle value at least 1.6-fold (0.22 log units) away from the limit.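

On the amide-type nitrogen, 4-chlorophenyl in place of benzyl amounts to an at least 8.4-fold higher number from compound 1 to compound 3 (0.92 log units; beyond the scatter). This shows that a second replacement at this end of the molecule, of a different kind from the fluoro step, also raises the number beyond the scatter, leaving compound 1 as the only one of the three with a readable value in this assay. Compound 3 is known only as a limit of the assay, so the step between compound 2 and compound 3 cannot be read, and 4-fluorobenzyl and 4-chlorophenyl cannot be ordered: the limit of > 100000 nM in this assay, at which 2 of the 3 values shown sit.

On these data alone, it stays open whether the chlorine or the change from benzyl to a directly attached ring carries the step from compound 1 to compound 3, which a plain phenyl or a 4-chlorobenzyl group on that nitrogen could separate. Also open, as far as these compounds go, is whether an amine in place of the halogen would return a readable value in this assay.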